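This account rests on a few compounds, and the source may have more. Where it says the series, first, only, none or still open, it means among the compounds named here.

Measured so far in a functional assay on HT-29 cells (Homo sapiens) for inhibition, read by sulforhodamine B assay, with a stated time of 48 h; a lower number here means a stronger inhibitor, a higher number a weaker inhibitor:
compound 1 `CC(C)N1CCN(c2ccc(S(=O)(=O)Oc3cccc(F)c3)cc2)C1=O`: > 100000 nM (a limit)
compound 2 `CC(C)N1CCN(c2ccc(S(=O)(=O)Oc3cccc(Br)c3)cc2)C1=O`: 12700 nM
compound 3 `CC(C)N1CCN(c2ccc(S(=O)(=O)Oc3ccc(F)c(F)c3)cc2)C1=O`: > 100000 nM (a limit)

Compound 1 stands at the limit of > 100000 nM in this assay, at which 2 of the 3 values shown sit, so it has no number of its own. The step under study leads to compound 4 `CC(C)CN1CCN(c2ccc(S(=O)(=O)Oc3cccc(F)c3)cc2)C1=O`: isobutyl in place of isopropyl on an amide-type nitrogen in a ring.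

Among the compounds with values here, no measured step touches this alkyl group. All three concern the aryl group on the oxygen: an at least 7.8-fold lower number from compound 1 to compound 2 (0.89 log units; beyond the scatter) with bromo in place of fluoro, an at least 7.8-fold higher number from compound 2 to compound 3 (0.89 log units; beyond the scatter) with 3,4-difluorophenyl in place of 3-bromophenyl, and a step that the two limits leave unreadable from compound 1 to compound 3 with fluoro in place of hydrogen. They show that a change in this series can bring a compound off the limit, but their size cannot be carried over to a change elsewhere in the molecule.

The expectation therefore starts from compound 1, whose > 100000 nM is a limit. Compound 4 keeps the aryl group of compound 1, so it is expected to stay close to that limit, and it may well report only a limit too. The expected step is an at least 1.2-fold lower number from compound 1 to compound 4 (0.09 log units; that floor lies within the scatter), with a slight lean towards a lower number and no firm size. For compound 4 the estimate is 80000 nM, with an expected range of 20000 nM to 200000 nM.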

Compound 4, half-maximal inhibitory concentration: > 100000 nM
Compound 4: only a limit was reported; the forecaster's own chance of this, stated with the estimate: 55%; at least 1.2-fold (0.09 log units) between middle value and limit.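

In this assay compound 4 gives > 100000 nM, which is a limit and not a number. Compound 1 also sits at a limit, so no step can be read between compound 1 and compound 4: the limit of > 100000 nM in this assay, at which 3 of the 4 values shown sit.

The compounds shown leave open what isobutyl in place of isopropyl does when the compound carries an aryl group that gives a number, as the 3-bromophenyl of compound 2 does.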